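The source may report more compounds than this note shows. Statements on the series, on what has been measured and on what is new or still open speak of the compounds shown alone.

Measured compounds:
compound 1 `COC1=C[C@H](O)[C@H](C/C=C(\C)CC/C=C(\C)CCC=C(C)C)[C@@H](C)C1=O` — > 30000 nM
compound 2 `COC1=CC(=O)C(C/C=C(\C)CC/C=C(\C)CCC=C(C)C)=C(C)C1=O` — > 30000 nM
compound 3 `COC1=C(OC)[C@H](OC(C)=O)[C@H](C/C=C(\C)CC/C=C(\C)C[C@H](O)/C=C(\C)C(=O)O)[C@@H](C)C1=O` — > 30000 nM

In a functional assay on PC-3 cells (Homo sapiens) for inhibition, read by sulforhodamine B assay, with a stated time of 48 h (a higher number here means a weaker inhibitor of growth, a lower number a stronger inhibitor of growth), compound 1 gives only a limit, > 30000 nM, and not a number. Compound 2 likewise reaches only the limit > 30000 nM in this assay. Compound 3 also stands at the limit > 30000 nM in this assay. So compound 1 is not placed relative to the others: all three sit at the limit of > 30000 nM in this assay, at which 3 of the 3 values shown sit, and no step between measured compounds can be read.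

The next compound, compound 4 `COC1=C[C@H](O)[C@H](C/C=C(\C)CC/C=C(\C)C[C@H](O)/C=C(\C)CO)[C@@H](C)C1=O`, differs from compound 1 by a group of 7 heavy atoms (5 carbon, 2 oxygen; no ring) in place of a group of 5 heavy atoms (5 carbon; no ring), on a saturated chain carbon bound to a double-bonded chain carbon. For the measured compounds named here, with every measured value at the limit, there is no measured step on which to size the change; the expectation is for no step beyond the scatter, with compound 4 most likely remaining at the limit too. Compound 4 is thus estimated at 40000 nM in this assay, within 8000 nM to 150000 nM, which is an expected step that the limit leaves unreadable from compound 1 to compound 4.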

Compound 4, concentration for 50% growth inhibition: > 30000 nM
Compound 4 gave a limit, no number; the forecaster's own chance of this, stated with the estimate: 75%; the middle value lies beyond the limit too.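

Compound 4, like compound 1, gives only a limit in this assay, and no step from compound 1 to compound 4 can be read: the limit of > 30000 nM in this assay, at which 4 of the 4 values shown sit.

The compounds shown leave open which change to the shared core or its side chain, if any, would give a measurable value in this assay.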